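Carbamate in place of cyclohexylcarbonyl amide on a benzothiazole core

This account rests on a few compounds, and the source may have more. Where it says the series, first, only, none or still open, it means among the compounds named here.

Measured compounds:
compound 1 `O=C(Nc1ccc2nc(NC(=O)C3CCCCC3)sc2c1)c1ccccc1F`: 0.14 ug/mL
compound 2 `O=C(Nc1ccc2nc(NC(=O)C3CCCCC3)sc2c1)c1c(Cl)cccc1Cl`: 0.015 ug/mL
compound 3 `Cc1nc(C)c(C(=O)Nc2ccc3nc(NC(=O)C4CCCCC4)sc3c2)s1`: 0.39 ug/mL

In a functional assay on WI-38 VA13 cells (Homo sapiens) for cytotoxicity (on this read-out lower numbers stand for an effect already at smaller amounts and higher numbers for an effect only at larger amounts of compound), compound 2 gives the lowest number of the three: a 9.3-fold lower number from compound 1 to compound 2 (0.97 log units; beyond the scatter), and compound 3 sits furthest away, since a 26-fold higher number from compound 2 to compound 3 (1.41 log units; beyond the scatter). Compound 4 `COCCOC(=O)Nc1nc2ccc(NC(=O)c3c(Cl)cccc3Cl)cc2s1` has not been measured. It differs from compound 2 in one place: 2-methoxyethoxy in place of cyclohexyl on a carbonyl carbon. The change lies on the carbonyl carbon that carries the cyclohexyl group, while all three measured steps change the other amide, the one bearing 2-fluorophenyl, 2,6-dichlorophenyl or 2,4-dimethyl-1,3-thiazol-5-yl. Going by the values given here, none of the measured steps therefore bears on this change, and the data give no guide to its direction. The expectation rests on compound 2 alone, with a wide range around its value. Compound 4 is expected to give 0.05 ug/mL, between 0.01 ug/mL and 0.3 ug/mL. This estimate means a 3.3-fold higher number from compound 2 to compound 4 (0.52 log units; beyond the scatter).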

Compound 4, half-maximal effective concentration: 0.011 ug/mL
Beside the measured number, compound 4's estimate is 4.5-fold (0.66 log units) above it; the measured number falls inside the stated range.
By their numbers in this assay, from the lowest: compounds 4 and 2 (each within the scatter of the next); then compound 1; then compound 3.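

In this assay, going by these compounds alone, the change gives the first reading on the carbonyl carbon that carries the cyclohexyl group, as all earlier steps changed the other amide. Replacing cyclohexyl, a ring of carbon only with 0 hydrogen-bond acceptors, by 2-methoxyethoxy, an open chain with 2 hydrogen-bond acceptors, leaves compound 2 and compound 4 indistinguishable (and a 1.4-fold lower number from compound 2 to compound 4 (0.13 log units; within the scatter)), so this read-out does not depend on keeping the cyclohexyl ring when the 2,6-dichlorophenyl amide is present. No measurement shown here offers an explanation for this outcome.

The compounds shown leave open whether the same replacement would give a similar result alongside the 2-fluorophenyl group of compound 1 or the 2,4-dimethyl-1,3-thiazol-5-yl group of compound 3. They also leave open how this position would respond to a terminal amine, a carboxylic acid or a longer chain.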